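A few compounds are considered here, and "the series" means these few. Any claim that something is new, unique, unknown or untested is made for them only; others in the source may bear on it.

Compound 1 `COc1ccc(CS(=O)(=O)/C=C/c2ccc(F)cc2)cc1` is the starting point. In a functional assay on DLD-1 cells (Homo sapiens) for antiproliferative activity, read by trypan blue exclusion (a lower number here means a stronger inhibitor, a higher number a weaker inhibitor), compound 1 gives 2000 nM. Compound 2 `COc1ccc(CS(=O)(=O)/C=C/c2ccc(F)cc2OC)cc1` differs from it by one change, (methoxy in place of hydrogen on an aromatic carbon), and in this assay compound 2 gives 15000 nM. That change produced a 7.5-fold higher number from compound 1 to compound 2 (0.88 log units; beyond the scatter). Compound 3 `COc1ccc(CS(=O)(=O)/C=C/c2ccc(OC)cc2OC)cc1` carries a further change, methoxy in place of fluoro on an aromatic carbon is not broken down here in the same way, but the step is recorded as an at least 1.3-fold higher number from compound 2 to compound 3 (0.12 log units; that floor lies within the scatter). In this assay compound 3 reaches only a limit, > 20000 nM, so no exact number is known for it. This is the limit of > 20000 nM in this assay, at which 1 of the 3 values shown sits.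

Compound 4 `COc1ccc(CS(=O)(=O)/C=C/c2ccc(OC)c(OC)c2OC)cc1` is not yet measured in this assay. It differs from compound 3 by methoxy in place of hydrogen on an aromatic carbon. The difference between the cores of compound 1 and compound 3 is not broken down here. The change from compound 3 to compound 4 is the same kind of change as that from compound 1 to compound 2, though the surroundings differ: in compound 2 the new methoxy sits ortho to a large group and meta to a fluoro group, whereas in compound 4 it sits ortho to two methoxy groups and meta to a large group.

The earlier instance of this change gave a 7.5-fold higher number from compound 1 to compound 2 (0.88 log units; beyond the scatter), and compound 3 already sits at a limit, so the step from compound 3 to compound 4 is expected to be a step that the limit leaves unreadable from compound 3 to compound 4 in this assay. Compound 4 is therefore estimated at 40000 nM, most likely again reported only as a limit.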

Compound 4, half-maximal inhibitory concentration: > 20000 nM
Compound 4: no number, only a limit; the forecaster's own chance of this, stated with the estimate: 85%; the middle value lies beyond the limit too.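

Among the compounds shown here, compound 3 and compound 4 both stop at a limit rather than an exact number in this assay and so no step between them can be read: the limit of > 20000 nM in this assay, at which 2 of the 4 values shown sit. The compounds shown leave open whether methoxy in place of hydrogen on the aromatic carbon changes the activity of compound 3 at all, since the true values of compound 3 and compound 4 remain unknown.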